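This account rests on a few compounds, and the source may have more. Where it says the series, first, only, none or still open, it means among the compounds named here.

In an ADME assay on HepG2 cells (Homo sapiens) for cytotoxicity, read by CellTiter-Glo and ATP content, with a stated time of 72 h (on this read-out lower numbers stand for an effect already at smaller amounts and higher numbers for an effect only at larger amounts of compound), compound 1 `CS(=O)(=O)c1ccc(C(=O)NCC(=O)N(Cc2ccccc2)Cc2ccccc2)cc1[N+](=O)[O-]` gives 11900 nM. Compound 2 `CC(C)N(C(=O)CNC(=O)c1ccc(S(C)(=O)=O)c([N+](=O)[O-])c1)C(C)C` gives > 27000 nM, which is a limit of the assay and not a number. Compound 3 `CN(Cc1ccccc1)C(=O)CNC(=O)c1ccc(S(C)(=O)=O)c([N+](=O)[O-])c1` has benzyl(methyl)amino in place of diisopropylamino on a carbonyl carbon. For the measured compounds named here, no measured pair differs in one place. With compound 1 at 11900 nM, which also carries benzyl, a modest shift towards smaller amounts is expected in this assay. The expected change, an at least 1.3-fold lower number from compound 2 to compound 3 (0.13 log units; that floor lies within the scatter), is small and may not exceed the scatter. The estimated value for compound 3 is 20000 nM, with an expected range from 10000 nM to 40000 nM.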

Compound 3, half-maximal effective concentration: > 27000 nM
Compound 3 ended at the assay's limit; the forecaster's own chance of this, stated with the estimate: 45%; middle value at least 1.3-fold (0.13 log units) away from the limit.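

In this assay, hydrogen in place of phenyl on a saturated chain carbon bound to an amide-type nitrogen gives an at least 2.2-fold higher number from compound 1 to compound 3 (0.35 log units; beyond the scatter). This shows that benzyl(methyl)amino on the carbonyl carbon does not keep the lower number seen with compound 1, so a single benzyl is not enough for it. The step between compound 2 and compound 3 cannot be read because both stand at a limit: the limit of > 27000 nM in this assay, at which 2 of the 3 values shown sit.

Going by these compounds, how compound 2 and compound 3 truly compare stays open. So does whether a carboxylic acid or a longer chain in place of that phenyl would give a readable number.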